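The source may report more compounds than this note shows. Statements on the series, on what has been measured and on what is new or still open speak of the compounds shown alone.

Measured so far:
compound 1 `COc1ccc(SCc2ccc(C(=O)Nc3ccccc3N)cc2)cc1` — 10.2%
compound 2 `CCc1ccc(SCc2ccc(C(=O)Nc3ccccc3N)cc2)cc1` — 19.6%

In a functional assay on A-375 cells (Homo sapiens) for inhibition, read by CCK-8 assay, with a stated time of 72 h, tested at 2 uM (on this read-out lower numbers stand for less inhibition of growth and higher numbers for more inhibition of growth at the one concentration tested), compound 2 stands highest of the two numbers, with compound 1 nearest at a number 9.4 percentage points higher from compound 1 to compound 2 (within the scatter). Compound 3 `CC(C)(C)c1ccc(SCc2ccc(C(=O)Nc3ccccc3N)cc2)cc1` differs from compound 2 by tert-butyl in place of ethyl on an aromatic carbon. For the measured compounds named here, the only step that bears on this change is the one from compound 1 to compound 2, a change at the same aromatic carbon, and it stayed within the scatter. No step beyond the scatter is known in this series, so the expected step for compound 3 is a number 2.4 percentage points higher from compound 2 to compound 3 (within the scatter), not beyond the scatter. Compound 3 is estimated at 22%, within 8% to 38%.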

Compound 3, percent growth inhibition at one concentration: 2.13%
Compound 3: the middle estimate sits 19.9 percentage points above what was measured, and the stated range ends above it.
By their numbers in this assay, from the lowest: compounds 3, 1 and 2 (each within the scatter of the next, the first and the last beyond it).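

In this assay, for the compounds shown here, tert-butyl in place of ethyl gives a number 17.5 percentage points lower from compound 2 to compound 3 (beyond the scatter) as the first step beyond the scatter at this aromatic carbon, para to a large group. Tert-butyl in place of methoxy gives only a number 8.1 percentage points lower from compound 1 to compound 3 (within the scatter) here, so the one resolved pair is ethyl against tert-butyl. Nothing at hand accounts for this step.

From the compounds shown here alone, whether an amine, a carboxylic acid or a longer chain at this carbon would shift the read-out stays open. Going by these compounds, how these three compounds compare at any other concentration also stays open.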